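The source may report more compounds than this note shows. Statements on the series, on what has been measured and on what is new or still open speak of the compounds shown alone.

Compound 1 `CCCc1ccc(NC2=CC(=O)c3nc4n(c3C2=O)[C@H]2OC[C@@H](O)[C@H]2OC4)cc1`: 4660 nM
Compound 2 `O=C1C(Nc2ccccc2)=CC(=O)c2c1nc1n2[C@H]2OC[C@@H](O)[C@H]2OC1`: > 4000 nM

In a functional assay on MCF7 cells (Homo sapiens) for inhibition, read by sulforhodamine B assay (a lower number here means a stronger inhibitor, a higher number a weaker inhibitor), compound 2 gives > 4000 nM, which is a limit of the assay and not a number. Its true potency is therefore unknown. Compound 3 `O=C1C(N2CCCC2)=CC(=O)c2c1nc1n2[C@H]2OC[C@@H](O)[C@H]2OC1` has pyrrolidin-1-yl in place of anilino on a double-bonded ring carbon. The change swaps a six-membered aromatic ring for a five-membered non-aromatic ring, and it leaves the shared core untouched. Going by the values given here, no measured pair of compounds shows this kind of swap, so the forecast has little to rest on. Among the compounds with values here, the only firm number is compound 1 at 4660 nM, and it suggests that this series is weak in this assay. The expected change is none beyond the scatter, in either direction: a number no higher from compound 2 to compound 3 (the limit leaves the size open). For compound 3, the estimated value is 4000 nM, with an expected range of 1200 nM to 15000 nM.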

Compound 3, half-maximal inhibitory concentration: > 16000 nM
Compound 3: a limit, no number (the forecaster's own chance of this, stated with the estimate: 30%); at least 4.0-fold (0.60 log units) between middle value and limit.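

Compound 2 gives > 4000 nM, which is a limit of the assay and not a number. Compound 3 gives > 16000 nM, also a limit, so no step can be read between compound 2 and compound 3. As far as these compounds go, whether pyrrolidin-1-yl in place of anilino changes potency at all remains open.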